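The source may hold more compounds than are shown below. What is called first, only, known or untested is meant among the compounds shown, and "the series" means these compounds.

Compound 2 `COc1ccc(CCc2nc3cc(-c4c(C)noc4C)ccc3n2[C@H]2CC[C@H](O)CC2)cc1Cl` gives the lowest number of the three compounds measured: in an assay on isolated protein for inhibition of histone acetyltransferase p300 (Homo sapiens), read by AlphaLISA, with a stated time of 20 min (on this read-out lower numbers stand for stronger inhibition and higher numbers for weaker inhibition), compound 2 gives 48 nM. Compound 1 `COc1ccc(CCc2nc3cc(-c4c(C)noc4C)ccc3n2[C@H]2CC[C@H](OC)CC2)cc1Cl` gives 97 nM in this assay, and compound 3 `COc1ccc(CCc2nc3cc(-c4c(C)noc4C)ccc3n2C2CCN(S(C)(=O)=O)CC2)cc1Cl` gives 148 nM. The change from compound 2 to compound 4 `Cc1noc(C)c1-c1ccc2c(c1)nc(C1CC1c1ccccc1)n2[C@H]1CC[C@H](O)CC1` is 2-phenylcyclopropyl in place of 2-(3-chloro-4-methoxyphenyl)ethyl on an aromatic carbon. For the measured compounds named here, none of the measured steps touches this group: the step of a 2.0-fold lower number from compound 1 to compound 2 (0.31 log units; beyond the scatter) and the step of a 3.1-fold higher number from compound 2 to compound 3 (0.49 log units; beyond the scatter) both change the group on the aromatic nitrogen, and the step of a 1.5-fold higher number from compound 1 to compound 3 (0.18 log units; within the scatter) does the same. They show that the shared core tolerates modest changes in potency from alterations at one position, but they say nothing about the group on the aromatic carbon. Going by the values given here, the expected step of a 3.1-fold higher number from compound 2 to compound 4 (0.49 log units; beyond the scatter) is therefore set as a modest weakening with a wide range, since no measured step supports a firmer call. Compound 4 is estimated to give 150 nM in this assay, with a range from 40 nM to 600 nM.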

Compound 4, half-maximal inhibitory concentration: 263 nM
For compound 4 the middle estimate is 1.8-fold (0.24 log units) below the measured one; low and high end bracket the measured number.
By their numbers in this assay, from the lowest: compound 2; then compounds 1, 3 and 4 (each within the scatter of the next, the first and the last beyond it).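

In this assay, for the compounds shown here, the change gives a 5.5-fold higher number from compound 2 to compound 4 (0.74 log units; beyond the scatter), so the group on the aromatic carbon, which no earlier step touched, does affect the number. The change is not a single edit, however: the 2-phenylcyclopropyl group differs from 2-(3-chloro-4-methoxyphenyl)ethyl both in its three-membered ring and in lacking the chlorine and the oxygen, and this one step cannot divide its size among these differences. No measurement shown here gives a reason for the step.

The compounds shown leave open whether the three-membered ring or the loss of the chloro and methoxy groups accounts for the step, which a plain 2-phenylethyl group or a 2-(3-chloro-4-methoxyphenyl)cyclopropyl group at this carbon could separate. From the compounds shown here alone, how a longer chain, such as 3-phenylpropyl, or an amine on the phenyl ring would fare here also remains open.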